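The source may report more compounds than this note shows. Statements on the series, on what has been measured and on what is new or still open speak of the compounds shown alone.

Four compounds with a shared sulfur-linked benzyl arm are compared in a functional assay on HeLa cells (Homo sapiens) for antiproliferative activity, read by MTT assay, with a stated time of 48 h; a higher number here means a weaker inhibitor, a lower number a stronger inhibitor. Compound 1 `Clc1ccc(CSc2nnc(-c3cnccn3)s2)cc1` gives 18900 nM in this assay. Compound 2 `Brc1ccc(CSc2nnc(-c3cnccn3)s2)cc1` gives 12400 nM. The change between them is bromo in place of chloro on an aromatic carbon, and it made a 1.5-fold lower number from compound 1 to compound 2 (0.18 log units; within the scatter).

Compound 3 `Clc1ccccc1CSc1nnc(-c2cnccn2)n1-c1ccccc1` carries a different core, and the difference between the two cores is not broken down here. In this assay compound 3 reaches only a limit, > 50000 nM. That value is the limit of > 50000 nM in this assay, at which 1 of the 3 values shown sits.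

Compound 4 `Brc1ccccc1CSc1nnc(-c2cnccn2)n1-c1ccccc1` has not yet been measured. It differs from compound 3 by bromo in place of chloro on an aromatic carbon. Among the compounds with values here, this is the same kind of change as the one from compound 1 to compound 2, but the place is not identical: there the bromo sat para to a large group, here it sits ortho to a large group. The expected step from compound 3 to compound 4 is a step that the limit leaves unreadable from compound 3 to compound 4, which rests on the small step seen in a 1.5-fold lower number from compound 1 to compound 2 (0.18 log units; within the scatter) and on compound 3 sitting at a limit. Compound 4 is therefore expected to give about 60000 nM, estimated between 30000 nM and 150000 nM, most likely again as a limit.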

Compound 4, half-maximal inhibitory concentration: > 50000 nM
Compound 4 ended at the assay's limit; the forecaster's own chance of this, stated with the estimate: 70%; the middle value lies beyond the limit too.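

Compound 3 and compound 4 both end at a limit rather than a number in this assay, so no step can be read from the change of chloro to bromo between them: the limit of > 50000 nM in this assay, at which 2 of the 4 values shown sit.

The compounds shown leave open whether that change alters activity on this core, and how far beyond the limit either compound lies.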